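Nitro in Place of Hydrogen: Expected Cell Tolerance

The compounds below may be only part of what the source reports. "The series", "measured", "known", "first", "only" and "open" are said of these compounds alone.

Of the compounds shown here, three have been tested in an ADME assay on Vero cells (Chlorocebus sabaeus) for cytotoxicity, read by MTT assay, with a stated time of 72 h; a higher number here means that more compound is tolerated, a lower number that less compound is tolerated. Compound 1 `Cc1ccccc1/C=N\NC(=S)N(Cc1ccccc1)Cc1ccccc1` gives 167000 nM. Compound 3 `Oc1ccccc1/C=N\NC(=S)N(Cc1ccccc1)Cc1ccccc1` gives 166000 nM; the step of a 1.0-fold lower number from compound 1 to compound 3 (0.00 log units; within the scatter) shows that a hydroxy in place of a methyl on an aromatic carbon left the number unchanged. Compound 2 `C=CCN(CC=C)C(=S)N/N=C(/C)c1ccccc1` gives 229000 nM, and its gaps to compound 1 and compound 3 both lie within the scatter, so the three numbers cannot be told apart.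

The new compound 4 `C=CCN(CC=C)C(=S)N/N=C(/C)c1ccc([N+](=O)[O-])cc1` differs from compound 2 only on the aromatic ring: nitro in place of hydrogen on an aromatic carbon. Within the data shown here, the only measured step that touches an aromatic carbon, from compound 1 to compound 3, involves a different group on a different core, so no measured step speaks directly to a nitro group here. With every measured change staying inside the scatter, a step within the scatter is also expected for a 1.1-fold lower number from compound 2 to compound 4 (0.06 log units; within the scatter). Compound 4 is therefore estimated at 200000 nM, with a range from 100000 nM to 400000 nM.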

Compound 4, half-maximal cytotoxic concentration: < 197000 nM
Compound 4 ended at the assay's limit; the forecaster's own chance of this, stated with the estimate: 10%; middle value at least 1.0-fold (0.00 log units) from the limit.
By their numbers in this assay, from the lowest: compounds 3, 1 and 2 (each within the scatter of the next).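

In this assay compound 4 gives < 197000 nM, which is a limit of the assay and not a number: the limit of < 197000 nM in this assay, at which 1 of the 4 values shown sits.

Nitro in place of hydrogen on an aromatic carbon, para to a large group, gives an at least 1.1-fold lower number from compound 2 to compound 4 (0.06 log units; that floor lies within the scatter), the only step shown on the core of compound 2. Unlike the earlier step, this one has only a floor, so the nitro compound may be tolerated no differently from compound 2 or at a clearly lower concentration, and the data cannot separate these two cases.

The compounds shown leave open how far the number of compound 4 lies past its limit. They also leave open whether an amine, a methoxy group or a chlorine atom in the same place would give a similar result, and how a nitro group would behave on the core of compound 1.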